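The compounds below may be only part of what the source reports. "The series", "measured", "known", "first", "only" and "open" are said of these compounds alone.

Three close relatives of compound 4 `Fc1cccc(-c2nc(Nc3ccccc3Br)c3cc(F)ccc3n2)c1` have already been tested. Compound 1 `Fc1ccc2nc(-c3ccccc3)nc(Nc3ccccc3)c2c1` gives in a functional assay on U-937 cells (Homo sapiens) for cytotoxicity, read by MTT assay, with a stated time of 48 h (on this read-out higher numbers stand for weaker inhibition and lower numbers for stronger inhibition), a value of > 50000 nM, which is a limit of the assay rather than a number. Compound 2 `Fc1cccc(-c2nc(Nc3ccccc3F)c3cc(F)ccc3n2)c1` likewise gives only the limit > 50000 nM in this assay. Compound 3 `Fc1cccc(-c2nc(Nc3ccc(Br)cc3)c3cc(F)ccc3n2)c1` also sits at the limit, giving > 50000 nM in this assay. Within the data shown here, the one step between measured neighbours, from compound 2 to compound 3, is therefore a step that the two limits leave unreadable from compound 2 to compound 3, and every value so far sits at the limit of > 50000 nM in this assay, at which 3 of the 3 values shown sit. Compound 4 differs from compound 2 by bromo in place of fluoro on an aromatic carbon. Because all three measured values rest at the limit of > 50000 nM in this assay, at which 3 of the 3 values shown sit, no direction or size for the new step can be read from them. Compound 4 is expected to give about 60000 nM, with a range from 20000 nM to 200000 nM, and the expected step from compound 2 to compound 4 is a step that the limit leaves unreadable from compound 2 to compound 4.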

Compound 4, half-maximal inhibitory concentration: > 50000 nM
Compound 4 was reported as a limit (the forecaster's own chance of this, stated with the estimate: 80%); the middle value is on the limit's open side.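

Compound 4 also gives only a limit, so its steps from compound 2 and from compound 3 cannot be read: the limit of > 50000 nM in this assay, at which 4 of the 4 values shown sit. The compounds shown leave open which change, if any, would give a measurable value in this assay at all.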